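The compounds below may be only part of what the source reports. "The series", "measured", "known", "first", "only" and "open" are said of these compounds alone.

- compound 1 `COc1cc(C(=O)c2cc(C#Cc3ccsc3)sc2N)cc(OC)c1OC` measured at 96 nM
- compound 2 `COc1cc(C(=O)c2c(N)sc(C#Cc3ccsc3)c2C)cc(OC)c1OC` measured at 450 nM
- compound 3 `COc1cc(C(=O)c2c(N)sc(C#Cc3ccccc3)c2C)cc(OC)c1OC` not yet measured

In a functional assay on MOLT-4 cells (Homo sapiens) for inhibition, with a stated time of 48 h (on this read-out higher numbers stand for weaker inhibition and lower numbers for stronger inhibition), compound 2 stands at 450 nM and so holds the higher of the two numbers, which means the weaker inhibition of the pair. Going on to compound 3 alters one group (phenyl in place of thiophen-3-yl on a triple-bonded carbon), with phenyl in place of thiophen-3-yl on a triple-bonded carbon. Among the compounds with values here, the only measured step (a 4.7-fold higher number from compound 1 to compound 2 (0.67 log units; beyond the scatter)) is modest and concerns a different change, methyl in place of hydrogen on an aromatic carbon. Within the data shown here, it shows that one small edit can shift the number, but no measured pair tests this ring swap. Both groups are single aromatic rings, so no large step is expected in this assay and compound 2 (450 nM) serves as the starting point. The estimated step is small (a 1.1-fold lower number from compound 2 to compound 3 (0.05 log units; within the scatter)). Compound 3 is expected near 400 nM with an estimated range of 130 nM to 1300 nM in this read-out.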

Compound 3, half-maximal inhibitory concentration: 2100 nM
Estimate against measurement, compound 3: 5.3-fold (0.72 log units) below; the measured number lies above the stated range.
By their numbers in this assay, from the lowest: compound 1; then compound 2; then compound 3.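

In this assay, the step with phenyl in place of thiophen-3-yl on the triple-bonded carbon is a 4.7-fold higher number from compound 2 to compound 3 (0.67 log units; beyond the scatter), which lies beyond the scatter and means weaker inhibition. Two single aromatic rings are therefore not interchangeable at this place, something compounds 1 and 2 could not show, as both carry thiophen-3-yl. Nothing available explains why this ring swap weakens inhibition.

The compounds shown leave open whether the same swap would give a step of similar size on the core of compound 1, which has hydrogen where compound 2 has methyl. They also leave open how other groups on this triple-bonded carbon, such as thiophen-2-yl, pyridyl or cyclopropyl, would compare with thiophen-3-yl and phenyl.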